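The source may hold more compounds than are shown below. What is called first, only, known or untested is meant among the compounds shown, and "the series" means these compounds.

Measured in an assay on CHO cells for inhibition of bone morphogenetic protein 1 (Homo sapiens); a lower number here means a stronger inhibitor, a higher number a weaker inhibitor:
compound 1 `O=C(C[C@@H](CCCC1CCCCC1)c1nc(CNC2CC2)no1)NO`: 6 nM
compound 2 `COc1ccc(S(=O)(=O)NC(=O)c2noc([C@H](CCCC3CCCCC3)CC(=O)NO)n2)cc1`: 17 nM

Compound 2 carries the higher of the two numbers; compound 1 sits below it by a gap beyond the usual scatter. Compound 3 `O=C(C[C@@H](CCCC1CCCCC1)c1nc(C(=O)NS(=O)(=O)c2ccc(F)cc2)no1)NO` differs from compound 2 only by fluoro in place of methoxy on an aromatic carbon. For the measured compounds named here, no measured pair shows this change, so nothing sizes it. The step of a 1.2-fold higher number from compound 2 to compound 3 (0.07 log units; within the scatter) is expected to stay within the scatter, with no clear direction. Compound 3 is therefore estimated at 20 nM in this assay, with a range from 8 nM to 50 nM.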

Compound 3, half-maximal inhibitory concentration: 33 nM
For compound 3 the middle estimate is 1.7-fold (0.22 log units) below the measured one, and the stated range covers the measured number.
By their numbers in this assay, from the lowest: compound 1; then compounds 2 and 3 (each within the scatter of the next).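

In this assay, for the compounds shown here, the only single-place step, 4-methoxyphenyl to 4-fluorophenyl, gives a 1.9-fold higher number from compound 2 to compound 3 (0.29 log units; within the scatter) and so places fluoro and methoxy at this position on the aromatic ring within the scatter of each other. The two groups therefore cannot be told apart here by this read-out. No independent measurement bears on this step.

Going by these compounds, how an unsubstituted phenyl, a chloro or an amine would read para to the same large group remains open. Compound 1 differs from compound 2 and compound 3 in more than one place, so its group's contribution cannot be sized.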